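The source may hold more compounds than are shown below. What is called first, only, known or untested is meant among the compounds shown, and "the series" means these compounds.

Measured compounds in a functional assay on BCG823 cells (Homo sapiens) for inhibition, read by MTT assay, with a stated time of 72 h; a lower number here means a stronger inhibitor, a higher number a weaker inhibitor:
Compound 1 `CN(C(=O)NC(=O)c1ccccc1F)c1nc(C(F)(F)F)c(C(=O)N/N=C/c2cccc(C(F)(F)F)c2)s1` gives 16.3 ug/mL.
Compound 2 `CN(C(=O)NC(=O)c1ccccc1F)c1nc(C(F)(F)F)c(C(=O)N/N=C/c2cc(C(F)(F)F)cc(C(F)(F)F)c2)s1` gives 4.23 ug/mL.
Compound 3 `CNc1nc(C(F)(F)F)c(C(=O)N/N=C/c2cc(C(F)(F)F)cc(C(F)(F)F)c2)s1` reaches only a limit, > 100 ug/mL, not a number.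

Compound 2 holds the lowest of the two numbers recorded; its nearest neighbour is compound 1, separated by a 3.9-fold lower number from compound 1 to compound 2 (0.59 log units; beyond the scatter). Compound 3 sits at the limit of > 100 ug/mL in this assay, at which 1 of the 3 values shown sits. The step of an at least 23-fold higher number from compound 2 to compound 3 (1.37 log units; beyond the scatter) is large and shows that the ((2-fluorophenyl)carbonyl)carbamoyl group on the ring nitrogen is needed for a low number.

Compound 4 `CN(C(=O)NC(=O)c1ccc(Cl)cc1Cl)c1nc(C(F)(F)F)c(C(=O)N/N=C/c2cc(C(F)(F)F)cc(C(F)(F)F)c2)s1` is not yet measured. It differs from compound 2 in 2,4-dichlorophenyl in place of 2-fluorophenyl on a carbonyl carbon. Neither measured step touches this part of the molecule: one adds trifluoromethyl on an aromatic carbon of the hydrazone aryl, the other removes the whole ((2-fluorophenyl)carbonyl)carbamoyl group. For the measured compounds named here, in compound 4 that group is kept and only its aryl is exchanged, so the large loss of an at least 23-fold higher number from compound 2 to compound 3 (1.37 log units; beyond the scatter) should not recur, and no measured step predicts a gain either. For compound 4 the expected step is a 1.1-fold higher number from compound 2 to compound 4 (0.03 log units; within the scatter), within the scatter. Compound 4 is therefore estimated at 4.5 ug/mL, with a range from 1.5 ug/mL to 13 ug/mL.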

Compound 4, half-maximal inhibitory concentration: > 100 ug/mL
Compound 4 was reported as a limit (the forecaster's own chance of this, stated with the estimate: 5%); middle value at least 22-fold (1.34 log units) away from the limit.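

In this assay the aryl on the carbonyl carbon proves to be no free position: exchanging 2-fluorophenyl for 2,4-dichlorophenyl, with the rest of the molecule kept, gives an at least 23-fold higher number from compound 2 to compound 4 (1.37 log units; beyond the scatter). The reading for compound 4, > 100 ug/mL, is a limit and not a number. Retaining the ((2-fluorophenyl)carbonyl)carbamoyl framework therefore does not by itself give a low number, and exchanging its aryl alone ends at the same reading as removing the whole group: the limit of > 100 ug/mL in this assay, at which 2 of the 4 values shown sit.

On these data alone, whether the loss follows the departure of the fluorine or the arrival of one or both chlorines stays open, and a 2-chlorophenyl or a 4-chlorophenyl on the same carbonyl carbon would separate these. Also open, as far as these compounds go, is whether any other aryl there, such as plain phenyl or 4-methoxyphenyl, keeps a low number.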